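Removal of the ester aryl group in the cyclohexyl anilide series

The source may hold more compounds than are shown below. What is called first, only, known or untested is meant among the compounds shown, and "the series" means these compounds.

Compound 2 `O=C(OC1(C(=O)Nc2ccc([N+](=O)[O-])cc2)CCCCC1)c1ccc([N+](=O)[O-])cc1` holds the lowest number of the three measured in a functional assay on HepG2 cells (Homo sapiens) for inhibition, read by MTT assay, with a stated time of 72 h (a lower number here means a stronger inhibitor, a higher number a weaker inhibitor), giving 14.1 nM. Compound 1 `O=C(OC1(C(=O)Nc2ccc([N+](=O)[O-])cc2)CCCCC1)c1ccc(C(F)(F)F)cc1` gives 29.1 nM, and the step of a 2.1-fold lower number from compound 1 to compound 2 (0.31 log units; beyond the scatter). Compound 3 `CCOC(=O)c1ccccc1C(=O)OC1(C(=O)Nc2ccc([N+](=O)[O-])cc2)CCCCC1` gives 517 nM, the highest number of the three. Compound 4 `O=COC1(C(=O)Nc2ccc([N+](=O)[O-])cc2)CCCCC1` differs from compound 2 by hydrogen in place of 4-nitrophenyl on a carbonyl carbon, so only a hydrogen remains on that carbonyl carbon. Within the data shown here, no measured step removes the aryl group entirely: the single one-place step, a 2.1-fold lower number from compound 1 to compound 2 (0.31 log units; beyond the scatter), only exchanges a substituent on that ring and is modest. Compound 3, which carries a different aryl ester, shows a value in this assay well above that of compound 2, so the nature of the ester aryl does move the number. Dropping the whole 4-nitrophenyl is therefore expected to raise the number by more than either comparison shows; the estimated step is a 110-fold higher number from compound 2 to compound 4 (2.03 log units; beyond the scatter). Compound 4 is expected to give about 1500 nM in this assay, within a range of 300 nM to 8000 nM.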

Compound 4, half-maximal inhibitory concentration: 34.1 nM
For compound 4 the middle estimate is 44-fold (1.64 log units) above the measured one; measured number below the stated range.
By their numbers in this assay, from the lowest: compound 2; then compounds 1 and 4 (each within the scatter of the next); then compound 3.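

In this assay, the 4-nitrophenyl on this carbonyl carbon is not needed for a number in the range of the aryl esters: hydrogen in its place gives a 2.4-fold higher number from compound 2 to compound 4 (0.38 log units; beyond the scatter), which is a modest step. The matching exchange of 4-(trifluoromethyl)phenyl for hydrogen gives a 1.2-fold higher number from compound 1 to compound 4 (0.07 log units; within the scatter), so at this position that aryl group leaves no readable mark on the number. Nothing measured on these compounds accounts for this result.

Open, on these data alone, is whether a methyl group or a longer alkyl chain on this carbonyl carbon would keep the number of compound 4 or shift it. Also open, as far as these compounds go, is how an amine at this carbonyl carbon, or a free hydroxyl in place of the whole ester, would read in this assay.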